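This account rests on a few compounds, and the source may have more. Where it says the series, first, only, none or still open, it means among the compounds named here.

In a functional assay (aorta) with Oryctolagus cuniculus as the target (a higher number here means weaker binding, a lower number tighter binding), compound 1 (`COc1cc(C(C)=O)ccc1OCCCN1CCC(C(c2ccc(F)cc2)c2ccc(F)cc2)CC1`) gives 1.59 nM, compound 2 (`COc1cc(C(=O)O)ccc1OCCCN1CCC(C(c2ccc(F)cc2)c2ccc(F)cc2)CC1`) gives 79.4 nM and compound 3 (`N#Cc1ccc(OCCCN2CCC(C(c3ccc(F)cc3)c3ccc(F)cc3)CC2)cc1`) gives 5.01 nM. Compound 3 therefore holds the middle number of the three, nearer to compound 1 than to compound 2. Compound 4 (`CC(C)(C)c1ccc(OCCCN2CCC(C(c3ccc(F)cc3)c3ccc(F)cc3)CC2)cc1`) has tert-butyl in place of the cyano of compound 3 on an aromatic carbon: tert-butyl in place of cyano on an aromatic carbon. Among the measured compounds shown here, no measured step makes this exact swap. The closest guide is the modest 3.2-fold higher number from compound 1 to compound 3 (0.50 log units; beyond the scatter). The large 50-fold higher number from compound 1 to compound 2 (1.70 log units; beyond the scatter) and a 16-fold lower number from compound 2 to compound 3 (1.20 log units; beyond the scatter) both involve the carboxy group of compound 2, which compound 4 lacks, so they bear on it less. In this assay, the expected change is no step beyond the scatter, with a 1.2-fold higher number from compound 3 to compound 4 (0.08 log units; within the scatter) as the estimate. For compound 4 the estimated value is 6 nM, with an expected range of 1.5 nM to 25 nM.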

Compound 4, dissociation constant: 1 nM
Estimate against measurement, compound 4: 6.0-fold (0.78 log units) above, outside the stated range (below it).
By their numbers in this assay, from the lowest: compounds 4 and 1 (each within the scatter of the next); then compound 3; then compound 2.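

In this assay this ring position does not depend on a nitrile: tert-butyl, with no hydrogen-bond acceptor, gives a 5.0-fold lower number from compound 3 to compound 4 (0.70 log units; beyond the scatter) and so a tighter number. The wider swaps give a 79-fold lower number from compound 2 to compound 4 (1.90 log units; beyond the scatter) and a 1.6-fold lower number from compound 1 to compound 4 (0.20 log units; within the scatter), which sets compound 4 far from the carboxy compound while leaving it within the scatter of the acetyl compound. Nothing shown explains why tert-butyl behaves this way.

On these data alone, whether an isopropyl group or an amine at this same place would follow tert-butyl or the nitrile remains open.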